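This account rests on a few compounds, and the source may have more. Where it says the series, first, only, none or still open, it means among the compounds named here.

Compound 1 `CCCNC(=O)c1cc(Oc2ccc(NC(=O)c3cc4cccnc4n(-c4ccccc4F)c3=O)cc2)ccn1`: 150 nM in a functional assay on A549 cells (Homo sapiens) for antiproliferative activity, read by MTT assay, with a stated time of 72 h; on this read-out lower numbers stand for stronger inhibition and higher numbers for weaker inhibition. Compound 2 `CCCNC(=O)c1cc(Oc2ccc(NC(=O)c3cc4cccnc4n(-c4ccc(C(F)(F)F)cc4Cl)c3=O)cc2)ccn1`: 1250 nM in this assay.

Among these two numbers, compound 2 gives the highest, with compound 1 the nearest at an 8.3-fold higher number from compound 1 to compound 2 (0.92 log units; beyond the scatter) apart. Compound 3 `CCCNC(=O)c1cc(Oc2ccc(NC(=O)c3cc4cccnc4n(-c4ccc(F)c(Cl)c4)c3=O)cc2)ccn1` is not yet measured; it differs from compound 2 in one place: 3-chloro-4-fluorophenyl in place of 2-chloro-4-(trifluoromethyl)phenyl on an aromatic nitrogen. Going by the values given here, the only measured step that touches the same place is the exchange of aryl groups from compound 1 to compound 2, and it moved the number by an 8.3-fold higher number from compound 1 to compound 2 (0.92 log units; beyond the scatter). A return partway toward the number of compound 1 is therefore expected, by about a 3.1-fold lower number from compound 2 to compound 3 (0.49 log units; beyond the scatter). Compound 3 is estimated at 400 nM, within a range of 120 nM to 1500 nM.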

Compound 3, half-maximal inhibitory concentration: 590 nM
The estimate for compound 3 lay 1.5-fold (0.17 log units) below the measured number; measured number inside the range.
By their numbers in this assay, from the lowest: compound 1; then compound 3; then compound 2.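

Placing 3-chloro-4-fluorophenyl on the aromatic nitrogen in place of 2-chloro-4-(trifluoromethyl)phenyl gives a 2.1-fold lower number from compound 2 to compound 3 (0.33 log units; beyond the scatter) in this assay, so a second exchange at this position also changes the number. Even so, the 2-fluorophenyl group keeps the lowest number of the three, with a 3.9-fold higher number from compound 1 to compound 3 (0.59 log units; beyond the scatter), and neither chlorine-bearing group matches it. Nothing available here explains these differences. The compounds shown leave open how a plain phenyl group, or a phenyl group carrying a methoxy group or an amine, would compare at this position.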